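From 2-Phenylethenyl to Ethoxycarbonyl: An Expected Step

This account rests on a few compounds, and the source may have more. Where it says the series, first, only, none or still open, it means among the compounds named here.

Measured compounds:
Compound 1 `Nc1nc(O)c2c(n1)n(C1OC(CO)[C@@H](O)[C@H]1O)c(=O)n2C/C=C/c1ccccc1`: in a functional assay on the whole organism (B cells) with Mus musculus as the target (a lower number here means a smaller maximal response, a higher number a larger maximal response), compound 1 reaches 73%.
Compound 2 `C=CCn1c(=S)n(C2OC(COCc3ccccc3)[C@H]3OC(C)(C)O[C@@H]23)c2nc(N)nc(O)c21`: in this assay compound 2 reaches 77%.

Of these two numbers, compound 1 holds the lower one, yet compound 2 sits within the usual scatter, so the two cannot be told apart. Compound 3 `CCOC(=O)Cn1c(=O)n(C2OC(CO)[C@@H](O)[C@H]2O)c2nc(N)nc(O)c21` is not yet measured. It differs from compound 1 in one place: ethoxycarbonyl in place of 2-phenylethenyl on a saturated chain carbon bound to an aromatic nitrogen. Among the compounds with values here, no measured pair shows what such a change does here. A modest downward step in this assay is expected, a number 10 percentage points lower from compound 1 to compound 3 (within the scatter), though it may well stay within the scatter. Compound 3 is therefore estimated at 63%, within 40% to 88%.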

Compound 3, largest response reached (reported as maximal response), in percent of the reference or control that the assay uses: 86%
Compound 3: middle estimate off by 23 percentage points, on the low side; low and high end bracket the measured number.
By their numbers in this assay, from the lowest: compounds 1, 2 and 3 (each within the scatter of the next, the first and the last beyond it).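

On a saturated chain carbon bound to an aromatic nitrogen, ethoxycarbonyl in place of 2-phenylethenyl gives, in this assay, a number 13 percentage points higher from compound 1 to compound 3 (beyond the scatter) and this is a step that can be told from noise. The six-membered aromatic ring of 2-phenylethenyl is therefore not needed for the response at this position, at least with this replacement. No measurement at hand explains the direction of this step. Still open, on these data alone, is which part of ethoxycarbonyl matters: a carboxylic acid or a primary amide on the same chain carbon would begin to show this.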